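Replacing 3-fluorophenyl with 2-chlorophenyl in the series

The source may hold more compounds than are shown below. What is called first, only, known or untested is meant among the compounds shown, and "the series" means these compounds.

In a functional assay on U-251 cells (Homo sapiens) for antiproliferative activity, read by MTT assay, with a stated time of 24 h (a higher number here means a weaker inhibitor, a lower number a stronger inhibitor), the measured compounds share one core and differ in the aryl group on a saturated chain carbon bound to an oxygen on an aromatic ring. Compound 1 `COc1cc(OC)c(-c2coc3cc(OCc4ccc([N+](=O)[O-])cc4)ccc3c2=O)cc1OC` gives 9400 nM, compound 2 `COc1cc(OC)c(-c2coc3cc(OCc4ccccc4C#N)ccc3c2=O)cc1OC` gives 980 nM, and compound 3 `COc1cc(OC)c(-c2coc3cc(OCc4cccc(F)c4)ccc3c2=O)cc1OC` gives 3510 nM. Compound 3 therefore stands in the middle of the three numbers, with compound 1 highest and compound 2 lowest.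

The next compound, compound 4 `COc1cc(OC)c(-c2coc3cc(OCc4ccccc4Cl)ccc3c2=O)cc1OC`, has 2-chlorophenyl in place of 3-fluorophenyl on a saturated chain carbon bound to an oxygen on an aromatic ring.

For the measured compounds named here, all three measured steps exchange this same group, and they show how far such changes have moved the number so far. The first is a 9.6-fold lower number from compound 1 to compound 2 (0.98 log units; beyond the scatter), the second is a 2.7-fold lower number from compound 1 to compound 3 (0.43 log units; beyond the scatter), and the third is a 3.6-fold higher number from compound 2 to compound 3 (0.55 log units; beyond the scatter). Going by the values given here, compound 2, at 980 nM, is the only measured compound whose group name also begins with 2, so it gives the expectation a slight pull towards lower numbers. Among the compounds with values here, that is a single compound, and no measured compound carries chlorine.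

A small move to a lower number is expected: a 2.0-fold lower number from compound 3 to compound 4 (0.29 log units; within the scatter). In this assay, the estimated value for compound 4 is 1800 nM, with an expected range from 700 nM to 4500 nM.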

Compound 4, half-maximal inhibitory concentration: > 10000 nM
Compound 4: only a limit was reported (the forecaster's own chance of this, stated with the estimate: 3%); at least 5.5-fold (0.74 log units) between middle value and limit.
By their numbers in this assay, from the lowest: compound 2; then compound 3; then compound 1. At a limit, above all of these: compound 4.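

In this assay, compound 4 is reported only as a limit and not as a number: the limit of > 10000 nM in this assay, at which 1 of the 4 values shown sits.

Within the series, 2-chlorophenyl on this saturated chain carbon bound to an oxygen on an aromatic ring gives a clear loss, seen in an at least 2.8-fold higher number from compound 3 to compound 4 (0.45 log units; beyond the scatter) and in the change of chloro in place of cyano on an aromatic carbon, an at least 10-fold higher number from compound 2 to compound 4 (1.00 log units; beyond the scatter), so the 2 in a group name does not by itself carry the low number of compound 2. Against the 4-nitrophenyl group the result reads an at least 1.0-fold higher number from compound 1 to compound 4 (0.02 log units; that floor lies within the scatter), and this pair therefore stays unordered, leaving 2-cyanophenyl as the only group here with a number near the low end.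

The compounds shown offer chlorine only as 2-chlorophenyl, so the effect of the atom cannot be separated from that of its place on the ring; 3-chlorophenyl and 2-fluorophenyl would divide the two. From the compounds shown here alone, whether the low number of compound 2 belongs to the nitrile alone also stays open, and 3-cyanophenyl or 4-cyanophenyl would test that.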